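The source may report more compounds than this note shows. Statements on the series, on what has been measured and on what is new or still open speak of the compounds shown alone.

Of the compounds shown here, three that share a core have been read in a physicochemical assay for solubility, in phosphate buffer, measured as kinetic solubility, at pH 7.4; on this read-out higher numbers stand for higher solubility and lower numbers for lower solubility. Compound 1 `Cc1oc(-c2ccc(Cl)cc2)nc1CN1CCC(C(=O)NCCCN2C[C@H](C)C[C@H](C)C2)CC1` gives > 72 ug/mL, which is a limit of the assay and not a number. Compound 3 `CCCN(CCC)CCNC(=O)C1CCN(Cc2nc(-c3ccccc3C)oc2C)CC1` gives > 65 ug/mL, which is also a limit. Going by the values given here, compound 2 `Cc1cccc(Cl)c1-c1nc(CN2CCC(C(=O)NCCCN3CCCC(C)C3)CC2)c(C)o1` is the only one with a plain number, at 52.6 ug/mL. Compound 1 therefore stands at a limit, and any step away from it has no exact starting point.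

Compound 4 `COc1cccc(Br)c1-c1nc(CN2CCC(C(=O)NCCCN3C[C@H](C)C[C@H](C)C3)CC2)c(C)o1` has not yet been measured. It keeps the core of compound 1 and changes one place, with 2-bromo-6-methoxyphenyl in place of 4-chlorophenyl on an aromatic carbon. No measured pair among these compounds differs in one place, so the size of such a change has not been seen directly. The nearest guide is compound 2 at 52.6 ug/mL, whose phenyl ring, like that of compound 4, carries more than one group. A small fall in this assay is expected, no larger than the usual scatter, and the expected step is an at least 1.4-fold lower number from compound 1 to compound 4 (0.15 log units; that floor lies within the scatter). For compound 4 the estimated value is 50 ug/mL, with an expected range from 25 ug/mL to 85 ug/mL.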

Compound 4, solubility: > 83 ug/mL
Compound 4: a limit, no number (the forecaster's own chance of this, stated with the estimate: 30%); middle value at least 1.6-fold (0.22 log units) away from the limit.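

Compound 4 gives > 83 ug/mL in this assay, which is a limit of the assay and not a number. Compound 1 also stands at a limit, so the step between compound 1 and compound 4 cannot be read. The compounds shown leave open how far 2-bromo-6-methoxyphenyl in place of 4-chlorophenyl shifts the read-out in this assay, or in which direction.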